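The source may report more compounds than this note shows. Statements on the series, on what has been measured and on what is new or still open speak of the compounds shown alone.

Compound 1 `O=c1c(CSC(=S)N2CCCC2)coc2ccccc12` and compound 2 `COc1ccc2occ(CSC(=S)N3CCOCC3)c(=O)c2c1` have both been tested in a functional assay on LM7 cells (Homo sapiens) for antiproliferative activity, read by MTT assay, with a stated time of 72 h; a lower number here means a stronger inhibitor, a higher number a weaker inhibitor. In this assay compound 1 gives 6000 nM. For compound 2, this assay reports only a limit, > 40000 nM, not a number. That limit is the limit of > 40000 nM in this assay, at which 1 of the 2 values shown sits. Compound 3 `COc1ccc2occ(CSC(=S)N3CCCC3)c(=O)c2c1` differs from compound 2 by pyrrolidin-1-yl in place of morpholin-4-yl on a thiocarbonyl carbon. Going by the values given here, no measured pair isolates this change, so its size is uncertain; still, compound 1 carries the same pyrrolidin-1-yl group and gives 6000 nM, which hints that compound 3 could be stronger than compound 2. Compound 3 is therefore expected at about 15000 nM, within 5000 nM to 60000 nM, an expected step of an at least 2.6-fold lower number from compound 2 to compound 3 (0.42 log units; beyond the scatter).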

Compound 3, half-maximal inhibitory concentration: 6000 nM
For compound 3 the middle estimate is 2.5-fold (0.40 log units) above the measured one, and the stated range covers the measured number.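

In this assay, pyrrolidin-1-yl in place of morpholin-4-yl on a thiocarbonyl carbon, with the rest of the structure unchanged, gives an at least 6.6-fold lower number from compound 2 to compound 3 (0.82 log units; beyond the scatter). Compound 2 has only a limit, so this step gives a minimum size rather than an exact one: the limit of > 40000 nM in this assay, at which 1 of the 3 values shown sits. Methoxy in place of hydrogen on an aromatic carbon gives no change at the digits printed from compound 1 to compound 3 (within the scatter), so with pyrrolidin-1-yl present, that change makes no visible difference.

From the compounds shown here alone, whether piperidin-1-yl or an open-chain dimethylamino group on the thiocarbonyl carbon would perform like pyrrolidin-1-yl remains open. So does the effect of a methoxy group paired with morpholin-4-yl.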